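Ethylpiperazine in Place of Dimethylamino: Expected Growth Inhibition

The compounds below may be only part of what the source reports. "The series", "measured", "known", "first", "only" and "open" are said of these compounds alone.

Compound 1 `CCc1ccc(C(=O)Nc2ccc3nc(N4CCN(CC)CC4)cc(C)c3c2)cc1`: 3060 nM
Compound 2 `Cc1cc(N(C)C)nc2ccc(NC(=O)c3ccc(Cl)c(Cl)c3)cc12`: 33300 nM
Compound 3 `CCN1CCN(c2cc(C)c3cc(NC(=O)c4ccc(F)c(F)c4)ccc3n2)CC1`: 5230 nM

All three were measured in a functional assay on MCF7 cells (Homo sapiens) for antiproliferative activity, read by MTT assay, with a stated time of 72 h; a lower number here means a stronger inhibitor, a higher number a weaker inhibitor. Compound 2 stands highest of the three numbers, and both compound 1 and compound 3 lie below it by more than the scatter. Compound 4 `CCN1CCN(c2cc(C)c3cc(NC(=O)c4ccc(Cl)c(Cl)c4)ccc3n2)CC1` differs from compound 2 in one place: 4-ethylpiperazin-1-yl in place of dimethylamino on an aromatic carbon. Among the measured compounds shown here, the only known step, a 1.7-fold higher number from compound 1 to compound 3 (0.23 log units; within the scatter), concerns the group on the carbonyl carbon, not this change, so it bears on it only indirectly. Compound 4 carries the same 4-ethylpiperazin-1-yl as compound 1 and compound 3, whose numbers are far below that of compound 2, while keeping the carbonyl substituent of compound 2. Compound 4 is therefore expected to give a lower number, a step of a 6.1-fold lower number from compound 2 to compound 4 (0.78 log units; beyond the scatter). The estimate for compound 4 is 5500 nM, in a range from 2000 nM to 15000 nM.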

Compound 4, half-maximal inhibitory concentration: 1380 nM
Beside the measured number, compound 4's estimate is 4.0-fold (0.60 log units) above it, outside the stated range (below it).
By their numbers in this assay, from the lowest: compound 4; then compounds 1 and 3 (each within the scatter of the next); then compound 2.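

In this assay, this position, next to the ring nitrogen, now has a direct reading: the change of dimethylamino to 4-ethylpiperazin-1-yl gives a 24-fold lower number from compound 2 to compound 4 (1.38 log units; beyond the scatter), a step on the amine itself rather than on the carbonyl substituent. With 4-ethylpiperazin-1-yl held fixed, 3,4-dichlorophenyl on the carbonyl also separates from the other two groups, with a 3.8-fold lower number from compound 3 to compound 4 (0.58 log units; beyond the scatter) and a 2.2-fold lower number from compound 1 to compound 4 (0.35 log units; beyond the scatter). Nothing measured here accounts for these steps. Still open, on these data alone, is whether morpholine or unsubstituted piperazine at this carbon would give a similar step, and whether it would hold with 3,4-difluorophenyl or 4-ethylphenyl on the carbonyl.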